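Swapping a methoxyphenyl for a dichlorophenyl on the core

The source may hold more compounds than are shown below. What is called first, only, known or untested is meant among the compounds shown, and "the series" means these compounds.

Three compounds have been measured in an assay on CHO cells for displacement of a labelled ligand from prostaglandin E2 receptor EP1 subtype (Homo sapiens); on this read-out lower numbers stand for stronger inhibition and higher numbers for weaker inhibition:
Compound 1, `CCc1ccccc1N(Cc1nnc(Cc2ccc(Cl)cc2)o1)S(=O)(=O)c1ccc(C)cc1`: 398 nM
Compound 2, `COc1ccc(Cc2nnc(CN(c3cccc(Cl)c3C)S(=O)(=O)c3ccc(C)cc3)o2)cc1`: 6.31 nM
Compound 3, `CCOc1ccc(Cc2nnc(CN(c3cccc(Cl)c3C)S(=O)(=O)c3ccc(C)cc3)o2)cc1`: 3.98 nM

Compound 2 gives the second highest of the three numbers. Its nearest neighbour is compound 3, reached by a 1.6-fold lower number from compound 2 to compound 3 (0.20 log units; within the scatter). Compound 1 is much further away, with a value of 398 nM, whereas compound 2 gives 6.31 nM; but the two differ in more than one place, so no single step can be read from them.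

Compound 4, `Cc1ccc(S(=O)(=O)N(Cc2nnc(Cc3c(Cl)cccc3Cl)o2)c2cccc(Cl)c2C)cc1`, has not yet been measured. It differs from compound 2 in one place: 2,6-dichlorophenyl in place of 4-methoxyphenyl on a saturated chain carbon bound to an aromatic carbon. Seen one bond further out, this is 4-methoxybenzyl giving way to 2,6-dichlorobenzyl.

Among the measured compounds shown here, no measured step bears directly on this change. For the measured compounds named here, the only single step, from compound 2 to compound 3, touches the same group but replaces hydrogen with methyl on the chain carbon bound to the oxygen, and stays within the scatter. Here the oxygen and its single acceptor disappear entirely, so the expectation rests on no precedent. A moderate rise in the number is expected for compound 4, a 3.2-fold higher number from compound 2 to compound 4 (0.50 log units; beyond the scatter), with wide uncertainty. Compound 4 is therefore estimated at 20 nM, within a range from 5 nM to 80 nM in this assay.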

Compound 4, half-maximal inhibitory concentration: 63.1 nM
Estimate against measurement, compound 4: 3.2-fold (0.50 log units) below; measured number inside the range.
By their numbers in this assay, from the lowest: compounds 3 and 2 (each within the scatter of the next); then compound 4; then compound 1.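

Replacing 4-methoxyphenyl with 2,6-dichlorophenyl on the saturated chain carbon bound to an aromatic carbon gives, in this assay, a 10-fold higher number from compound 2 to compound 4 (1.00 log units; beyond the scatter) and a 16-fold higher number from compound 3 to compound 4 (1.20 log units; beyond the scatter). Among these compounds, this is the first single change at this place to lie beyond the scatter, whereas the only earlier one, extending the 4-methoxyphenyl to 4-ethoxyphenyl, gave a 1.6-fold lower number from compound 2 to compound 3 (0.20 log units; within the scatter). Nothing available here explains the rise in the number.

The swap removes the methoxy group and adds two chlorines in a single step, leaving open which of these changes matters, or whether both do. From the compounds shown here alone, it is also open how an unsubstituted phenyl or a 2-chlorophenyl would read at this place.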